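A few compounds are considered here, and "the series" means these few. Any claim that something is new, unique, unknown or untested is made for them only; others in the source may bear on it.

Working notes on the series. Compound 1 `COC(=O)CCNC(=O)[C@@H]1O[P@](=O)(OCOC(=O)c2scnc2C(C)(C)C)OCC1(C)C`, compound 2 `COC(=O)CCNC(=O)[C@@H]1O[P@](=O)(OCOC(=O)c2cc(C)nn2C)OCC1(C)C` and compound 3 `COC(=O)CCNC(=O)[C@@H]1O[P@@](=O)(OCOC(=O)c2cc(C)nn2C)OCC1(C)C` have been measured; compound 4 `COC(=O)CCNC(=O)[C@@H]1O[P@@](=O)(OCOC(=O)c2scnc2C(C)(C)C)OCC1(C)C` has not. In an ADME assay on blood (Homo sapiens) for pharmacokinetics (a higher number here means that the compound lasts longer, a lower number that the compound disappears faster), compound 1 gives 0.44 h. Compound 2 reaches only a limit of this assay, < 0.16 h. Compound 3 also sits at a limit of this assay, > 1 h.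

Two steps can be read. The step of an at least 2.7-fold higher number from compound 2 to compound 1 (0.43 log units; beyond the scatter) follows the change (4-(tert-butyl)-1,3-thiazol-5-yl in place of 1,3-dimethyl-1H-pyrazol-5-yl on a carbonyl carbon), and its size is only bounded from one side because of the limit of < 0.16 h in this assay, at which 1 of the 3 values shown sits. The step of an at least 6.2-fold higher number from compound 2 to compound 3 (0.79 log units; beyond the scatter) involves no change of atoms or bonds; the two cores differ in that (the two compounds have the same atoms and bonds and differ only in configuration as drawn: 1 of 2 stereo elements differ; a stereocentre at a phosphorus is drawn R in compound 2 and S in compound 3), which is all that separates them because of the fact that compounds 2 and 3 differ only in the configuration as drawn, and the size of this step is open at the top because of the limit of > 1 h in this assay, at which 1 of the 3 values shown sits.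

Compound 4 differs from compound 3 by 4-(tert-butyl)-1,3-thiazol-5-yl in place of 1,3-dimethyl-1H-pyrazol-5-yl on a carbonyl carbon, the same change, at the same place, that was made from compound 2 to compound 1. For the measured compounds named here, the step expected in this assay is a step that the limit leaves unreadable from compound 3 to compound 4, set beside an at least 2.7-fold higher number from compound 2 to compound 1 (0.43 log units; beyond the scatter) as the only measured instance of this change. Its reference point is a limit, so the expectation carries wide bounds. For compound 4 the expected half-life in this assay is 2.2 h, estimated to fall between 0.9 h and 6 h.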

Compound 4, half-life: > 1 h
Compound 4 ended at the assay's limit (the forecaster's own chance of this, stated with the estimate: 60%); the middle value does not contradict the limit.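

In this assay compound 4 gives > 1 h, a limit and not a number, and compound 3 stands at the same limit, so the step between them cannot be read. 4-(tert-butyl)-1,3-thiazol-5-yl in place of 1,3-dimethyl-1H-pyrazol-5-yl therefore has one bounded instance, an at least 2.7-fold higher number from compound 2 to compound 1 (0.43 log units; beyond the scatter), and the core of compound 3 neither confirms nor contradicts it. What does recur is the step at phosphorus, which appears with 4-(tert-butyl)-1,3-thiazol-5-yl as an at least 2.2-fold higher number from compound 1 to compound 4 (0.35 log units; beyond the scatter) and points the same way as an at least 6.2-fold higher number from compound 2 to compound 3 (0.79 log units; beyond the scatter), both open at the top, with no compound shown against it, and in the first pair the stereocentre alone separates the two: the fact that compounds 1 and 4 differ only in the configuration as drawn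

Open, as far as these compounds go, is how far compound 3 and compound 4 lie past their limit, and with it whether the two groups on the carbonyl carbon differ at all when phosphorus is drawn S. Also open is whether the step at phosphorus holds with a phenyl ring on that carbonyl carbon, or with a carboxylic acid in place of the methyl ester on the side chain.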